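Amide aryl swap toward a cyanothiazole partner

The compounds below may be only part of what the source reports. "The series", "measured", "known", "first", "only" and "open" are said of these compounds alone.

Compound 1 `CC(C)[C@H](C(=O)Nc1ccc(F)cn1)c1ccc(Cl)cc1`, in a functional assay on CHO cells for agonist activity at Free fatty acid receptor 2 (Homo sapiens), read by cAMP accumulation; a lower number here means a stronger inhibitor, a higher number a weaker inhibitor: 1300 nM
Compound 2 `CC(C)C(C(=O)Nc1nc2ccccc2s1)c1ccc(Cl)cc1`, in this assay: 3000 nM

Of the two measured numbers, compound 1 has the lower one; compound 2 sits beyond the usual scatter from it. Compound 3 `CC(C)[C@H](C(=O)Nc1ncc(C#N)s1)c1ccc(Cl)cc1` is not yet measured. It differs from compound 1 in one place: 5-cyano-1,3-thiazol-2-yl in place of 5-fluoropyridin-2-yl on an amide-type nitrogen. For the measured compounds named here, no step between measured compounds isolates this change, so any expectation rests on compound 1 alone. The step from compound 1 to compound 3 is expected to be a 1.6-fold lower number from compound 1 to compound 3 (0.21 log units; within the scatter), a modest gain rather than one that is clearly outside the scatter. Compound 3 is estimated at 800 nM, within 250 nM to 2500 nM.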

Compound 3, half-maximal inhibitory concentration: 2000 nM
Beside the measured number, compound 3's estimate is 2.5-fold (0.40 log units) below it, and the stated range covers the measured number.
By their numbers in this assay, from the lowest: compounds 1, 3 and 2 (each within the scatter of the next, the first and the last beyond it).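

With a 1.5-fold higher number from compound 1 to compound 3 (0.19 log units; within the scatter) in this assay the amide nitrogen carries 5-cyano-1,3-thiazol-2-yl in place of 5-fluoropyridin-2-yl without a change beyond the scatter. At this position, then, a five-membered aromatic ring bearing a nitrile reads alike with a six-membered aromatic ring bearing fluorine on the shared core. No measurement shown here offers an explanation for this result. Going by these compounds, the ring and its substituent change together in this step, so their separate contributions remain open. Also open, on these data alone, is whether a carboxylic acid in place of the nitrile would keep the number within the scatter.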